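Notes on the sulfur-linked side chain of the shared core

The source may hold more compounds than are shown below. What is called first, only, known or untested is meant among the compounds shown, and "the series" means these compounds.

Compound 3 `CC1CCN(CCCSc2nc(C(F)(F)F)ccc2CNC(=O)C(C)c2ccc(NS(C)(=O)=O)c(F)c2)CC1` gives 2.9 nM in an assay on CHO-K1 cells for antagonist activity at transient receptor potential cation channel subfamily V member 1 (Homo sapiens), read by FLIPR; on this read-out lower numbers stand for stronger inhibition and higher numbers for weaker inhibition. On the numbers as they stand it is second highest of three; compound 2 `CC(C(=O)NCc1ccc(C(F)(F)F)nc1SCCCN1CCCCC1)c1ccc(NS(C)(=O)=O)c(F)c1` with 3 nM is nearest, and the two differ only by a 1.0-fold lower number from compound 2 to compound 3 (0.01 log units; within the scatter), so nothing separates them. Compound 1 `CC(C)CCSc1nc(C(F)(F)F)ccc1CNC(=O)C(C)c1ccc(NS(C)(=O)=O)c(F)c1` gives 0.7 nM, the lowest number of the set, and both a 4.1-fold higher number from compound 1 to compound 3 (0.62 log units; beyond the scatter) and a 4.3-fold higher number from compound 1 to compound 2 (0.63 log units; beyond the scatter) lie beyond the scatter.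

Compound 4 `CC(C(=O)NCc1ccc(C(F)(F)F)nc1[S+]([O-])C1CCCCC1)c1ccc(NS(C)(=O)=O)c(F)c1` has not been measured. The change from compound 3 is a group of 8 heavy atoms (6 carbon, 1 oxygen, 1 sulfur; one six-membered non-aromatic ring of carbon only) in place of a group of 11 heavy atoms (9 carbon, 1 nitrogen, 1 sulfur; one six-membered non-aromatic ring with 1 hetero atom), on an aromatic carbon. The group that leaves carries the six-membered non-aromatic ring with one hetero atom; the group that enters carries a six-membered non-aromatic ring of carbon only and an oxygen on the sulfur, with one hydrogen-bond acceptor instead of two.

The steps of a 4.3-fold higher number from compound 1 to compound 2 (0.63 log units; beyond the scatter) and a 4.1-fold higher number from compound 1 to compound 3 (0.62 log units; beyond the scatter) show that putting the ring with one hetero atom on the chain raised the number modestly; compound 4 drops that ring again, which points back towards compound 1. Among the measured compounds shown here, no measured pair covers the oxygen on sulfur or a ring bound directly to sulfur, so that part of the change has no precedent here. The step expected in this assay is a 1.2-fold lower number from compound 3 to compound 4 (0.06 log units; within the scatter), a modest lowering with a wide range. Compound 4 is estimated at 2.5 nM, between 0.5 nM and 15 nM.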

Compound 4, inhibition constant: "not active" (no number reported)
Nothing numeric was reported for compound 4, and the estimate cannot be compared.
By their numbers in this assay, from the lowest: compound 1; then compounds 3 and 2 (each within the scatter of the next).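

In this assay, among the compounds shown here, compound 4 is reported as "not active", without a number, so no step linking it to compound 1, compound 2 or compound 3 can be read. The compounds shown leave open whether the oxygen on the sulfur or the carbocyclic ring on that sulfur goes with this result. Nothing available bears on its cause.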